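Adding a third methoxy to compound 1

The source may hold more compounds than are shown below. What is called first, only, known or untested is meant among the compounds shown, and "the series" means these compounds.

Compound 1 `COc1ccc(C(O)C#CCOCc2ccc(SC)cc2)cc1OC` is examined in an assay on isolated protein for inhibition of Polyunsaturated fatty acid 5-lipoxygenase (Homo sapiens); a higher number here means a weaker inhibitor, a lower number a stronger inhibitor. In this assay compound 1 gives 80000 nM. Among the numbers shown, compound 1 stands highest: compound 3 `CSc1ccc(COCC#CC(O)c2ccc(C(C)C)cc2)cc1` gives 8000 nM in this assay. For compound 2 `COc1ccc(C(O)C#CCOCc2ccc(SC)cc2)cc1` this assay reports only a limit, > 100000 nM, not a number. The step of an at least 1.2-fold higher number from compound 1 to compound 2 (0.09 log units; that floor lies within the scatter) is therefore only a floor, and the step of an at least 12-fold lower number from compound 2 to compound 3 (1.09 log units; beyond the scatter) is large. Compound 4 `COc1cc(C(O)C#CCOCc2ccc(SC)cc2)cc(OC)c1OC` is not yet measured. It differs from compound 1 as follows: methoxy in place of hydrogen on an aromatic carbon. Among the measured compounds shown here, the only measured step that touches a methoxy on this ring, an at least 1.2-fold higher number from compound 1 to compound 2 (0.09 log units; that floor lies within the scatter), shows no clear effect of removing one; adding one is the reverse change, and the large step of an at least 12-fold lower number from compound 2 to compound 3 (1.09 log units; beyond the scatter) concerns a different group. A step of compound 4 beyond the scatter is therefore not expected, and the number is expected near the top of the range seen so far, as a 1.3-fold higher number from compound 1 to compound 4 (0.10 log units; within the scatter). Compound 4 is estimated at 100000 nM, between 30000 nM and 300000 nM in this assay.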

Compound 4, half-maximal inhibitory concentration: 80000 nM
Compound 4: the middle estimate sits 1.3-fold (0.10 log units) above what was measured, within the range that was stated.
By their numbers in this assay, from the lowest: compound 3; then compounds 1 and 4 (each within the scatter of the next). At a limit, above all of these: compound 2.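

In this assay the step is no change at the digits printed from compound 1 to compound 4 (within the scatter), and this time it rests on two true numbers. A methoxy on this carbon, ortho to a methoxy group and meta to a large group, therefore leaves inhibition unmoved in compound 4, a clear reading that the earlier methoxy step on this ring could not give. That earlier step remains only a floor because compound 2 is reported as a limit and not a number: the limit of > 100000 nM in this assay, at which 1 of the 4 values shown sits.

Going by these compounds, whether other groups behave the same way on this carbon stays open, for instance a hydroxyl, a chlorine or an ethoxy. Also open, on these data alone, is whether a third methoxy would remain without effect on a ring that carries the isopropyl of compound 3.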